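The compounds below may be only part of what the source reports. "The series", "measured", "known", "first", "only" and "open" are said of these compounds alone.

Measured so far:
compound 1, `C=C[C@@]1(C)O[C@H]1C[C@H]1C(=C)CC[C@@H]2[C@]1(C)CCC[C@]2(C)C(=O)O`: > 40000 nM
compound 2, `C=CC(=C)CC[C@@H]1[C@@]2(C)CCC[C@](C)(COC(=O)/C=C/c3ccc(O)c(OC)c3)[C@@H]2CC[C@@]1(C)O`: 14300 nM

Both compounds were run in a functional assay on HL-60 cells (Homo sapiens) for cytotoxicity, read by MTT assay, with a stated time of 48 h; a higher number here means a weaker inhibitor, a lower number a stronger inhibitor. For compound 1 the result of > 40000 nM is a limit of this assay rather than a number, as the limit of > 40000 nM in this assay, at which 1 of the 2 values shown sits, records. Compound 2 gives 14300 nM in this assay, a measured number. Among the compounds with values here, no step between two measured compounds differing in a single place is available, so compound 2 serves only to show the range in which this series has been read.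

The next compound, compound 3, `C=C[C@]1(C)O[C@H]1C[C@H]1C(=C)CC[C@@H]2[C@]1(C)CCC[C@]2(C)C(=O)O`, is compared with compound 1. The change is the two compounds have the same atoms and bonds and differ only in configuration as drawn: 1 of 6 stereo elements differ; a stereocentre at a saturated ring carbon is drawn R in compound 1 and S in compound 3. Within the data shown here, since compound 1 itself stands only at a limit, no measured step fixes the size of the effect of such a change. With a single stereocentre drawn the other way and nothing leaving or entering, the expected step in this assay is none beyond the scatter, and a further limit is the most likely outcome. The estimate for compound 3 in this assay is 40000 nM, with a range from 15000 nM to 100000 nM. The expected step is a number no higher from compound 1 to compound 3 (the limit leaves the size open).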

Compound 3, half-maximal inhibitory concentration: > 40000 nM
Compound 3 was reported as a limit; the forecaster's own chance of this, stated with the estimate: 60%; the middle value sits exactly at the limit.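

Compound 1 and compound 3 both stand at a limit in this assay, so no step can be read between them: the limit of > 40000 nM in this assay, at which 2 of the 3 values shown sit.

The compounds shown leave open whether drawing this one stereocentre R or S changes the result in this assay, as neither compound 1 nor compound 3 gives a measured number.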